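A Methoxy Group on the Benzoyl Ring of Compound 3

The compounds below may be only part of what the source reports. "The series", "measured", "known", "first", "only" and "open" are said of these compounds alone.

Compound 1, `COc1cc(-c2nnc3n2NC(c2cccs2)C(C(=O)c2ccccc2)S3)cc(OC)c1OC`, gives 86300 nM in a functional assay on PC-3 cells (Homo sapiens) for cytotoxicity, read by MTT assay, with a stated time of 48 h; a lower number here means a stronger inhibitor, a higher number a weaker inhibitor. Compound 2, `COc1cc(-c2nnc3n2NC(c2cccs2)C(C(=O)c2ccc(F)cc2)S3)cc(OC)c1OC`, gives 27400 nM. Compound 3, `COc1cc(-c2nnc3n2NC(c2ccco2)C(C(=O)c2ccccc2)S3)cc(OC)c1OC`, gives 64300 nM.

Compound 3 thus sits between the other two. Its number is close to that of compound 1, since a 1.3-fold lower number from compound 1 to compound 3 (0.13 log units; within the scatter), a gap that counts as no real difference. Compound 2 returns a clearly lower number than compound 3, the two values standing apart by more than the usual scatter.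

Compound 4, `COc1cccc(C(=O)C2Sc3nnc(-c4cc(OC)c(OC)c(OC)c4)n3NC2c2ccco2)c1`, has not yet been measured. It differs from compound 3 in one place: methoxy in place of hydrogen on an aromatic carbon.

Within the data shown here, only one measured step touches the same benzoyl ring, namely a 3.1-fold lower number from compound 1 to compound 2 (0.50 log units; beyond the scatter), which was a modest move toward a stronger inhibitor. That step put a different group in a different place, so it is a loose guide at best. Among the measured compounds shown here, no measured pair shows a methoxy group entering this ring, and the other measured step, from compound 1 to compound 3, concerns the five-membered ring instead.

On this thin basis compound 4 is expected to land near compound 3, with a 1.3-fold lower number from compound 3 to compound 4 (0.11 log units; within the scatter) as the estimated shift and a wide band around it. The estimate for compound 4 is 50000 nM, expected to fall between 20000 nM and 130000 nM.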

Compound 4, half-maximal inhibitory concentration: 84600 nM
For compound 4 the middle estimate is 1.7-fold (0.23 log units) below the measured one; the range from low to high includes it.
By their numbers in this assay, from the lowest: compound 2; then compounds 3, 4 and 1 (each within the scatter of the next).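

In this assay, among these compounds, this is the first look at a group entering the benzoyl ring of the furan-2-yl compound: methoxy on an aromatic carbon, meta to a large group, gives a 1.3-fold higher number from compound 3 to compound 4 (0.12 log units; within the scatter) and that gap counts as no real difference. Among the compounds shown here, the number therefore does not respond measurably to this added methoxy, whereas the only earlier change on this ring, fluoro in place of hydrogen on the thiophen-2-yl compound, gave a 3.1-fold lower number from compound 1 to compound 2 (0.50 log units; beyond the scatter) and so stood clear of the scatter. Those two steps differ in the group and in the parent compound, and nothing measured here bears on why they read differently.

The compounds shown leave open whether a different group at this same place, such as an amine or a carboxylic acid, or a methoxy elsewhere on the ring, would move the number beyond the scatter. They also leave open whether fluoro would give a similar step on the furan-2-yl compound, and whether methoxy would stay as quiet on the thiophen-2-yl compound.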